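Swapping 4-methoxyphenyl for 3-hydroxyphenyl at the assay limit

The compounds below may be only part of what the source reports. "The series", "measured", "known", "first", "only" and "open" are said of these compounds alone.

Compound 1 `O=C1O/C(=C\Cn2cc(-c3ccc(Br)cc3)nn2)C(OCc2ccccc2)=C1OCc1ccccc1`: 24300 nM
Compound 2 `COc1ccc(-c2cn(C/C=C3\OC(=O)C(OCc4ccccc4)=C3OCc3ccccc3)nn2)cc1`: > 100000 nM (a limit)

In a functional assay on HeLa cells (Homo sapiens) for antiproliferative activity, read by MTT assay, with a stated time of 72 h (a higher number here means a weaker inhibitor, a lower number a stronger inhibitor), compound 2 stands at > 100000 nM, which is a limit and not a number. Compound 3 `O=C1O/C(=C\Cn2cc(-c3cccc(O)c3)nn2)C(OCc2ccccc2)=C1OCc1ccccc1` has 3-hydroxyphenyl in place of 4-methoxyphenyl on an aromatic carbon. Among the measured compounds shown here, only one measured step bears on this change, methoxy in place of bromo, and it is an at least 4.1-fold higher number from compound 1 to compound 2 (0.61 log units; beyond the scatter). On that single step, a modest move to a lower number is expected in this assay, estimated as an at least 1.6-fold lower number from compound 2 to compound 3 (0.22 log units; that floor lies within the scatter). For compound 3 the expected value is 60000 nM, with an estimated range of 20000 nM to 150000 nM.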

Compound 3, half-maximal inhibitory concentration: 74800 nM
Estimate against measurement, compound 3: 1.2-fold (0.10 log units) below; low and high end bracket the measured number.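

Against 4-methoxyphenyl, 3-hydroxyphenyl at this position shows an at least 1.3-fold lower number from compound 2 to compound 3 (0.12 log units; that floor lies within the scatter) in this assay. That step is only a floor, because compound 2 is a limit and not a number: the limit of > 100000 nM in this assay, at which 1 of the 3 values shown sits.

Against 4-bromophenyl, the same group shows a 3.1-fold higher number from compound 1 to compound 3 (0.49 log units; beyond the scatter), which leaves compound 1 the most potent of the three. The compounds shown do not separate the hydroxy group from its place on the phenyl ring, as both differ between compound 2 and compound 3. On these data alone, how an amine or a carboxylic acid on that phenyl ring would read in this assay also remains open.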